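A few compounds are considered here, and "the series" means these few. Any claim that something is new, unique, unknown or untested is made for them only; others in the source may bear on it.

Compound 1 `c1cnc2c(c1)CCC[C@@H]2N(CC1CC1)C[C@H]1Cc2c(cccc2N2CCNCC2)CN1` was examined in a functional assay on CCRF-CEM cells for agonist activity at C-X-C chemokine receptor type 4 (Homo sapiens), read by calcium flux, with a stated time of 25 min; a higher number here means that more compound is needed for the effect, a lower number that less compound is needed. In this assay compound 1 gives > 30000 nM, which is a limit of the assay and not a number. Compound 2 `CN(C[C@@H]1Cc2c(cccc2N2CCNCC2)CN1)[C@H]1CCCc2cccnc21` carries a methyl group on the amine nitrogen where compound 1 carries cyclopropylmethyl. In this assay compound 2 gives > 30000 nM, again a limit of the assay and not a number. Where compound 1 stands is thus told only by the limit of > 30000 nM in this assay, at which 2 of the 2 values shown sit, and no order between compound 1 and compound 2 can be drawn from two values that both stop at the limit.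

Compound 3 `CCN(C[C@H]1Cc2c(cccc2N2CCNCC2)CN1)[C@H]1CCCc2cccnc21` has not yet been measured. It differs from compound 1 by methyl in place of cyclopropyl on a saturated chain carbon bound to an amine nitrogen, so compound 3 carries ethyl on the amine nitrogen, with compound 1 carrying cyclopropylmethyl and compound 2 carrying methyl at that same place. Within the data shown here, no step between two measured compounds is available, and both measured neighbours sit at the limit. The expected step is a step that the limit leaves unreadable from compound 1 to compound 3, none beyond the scatter. For compound 3 the expected result in this assay is 40000 nM, with a range from 10000 nM to 150000 nM, and most likely this assay will again report only a limit.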

Compound 3, half-maximal effective concentration: > 30000 nM
Compound 3 was reported as a limit (the forecaster's own chance of this, stated with the estimate: 85%); the middle value lies beyond the limit too.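

In this assay compound 3 gives > 30000 nM, which is a limit of the assay and not a number. No step from compound 1 to compound 3 can therefore be read, and the compounds share a single reading: the limit of > 30000 nM in this assay, at which 3 of the 3 values shown sit.

The compounds shown leave open whether cyclopropylmethyl, ethyl or methyl on the amine nitrogen makes any difference in this assay.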